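Piperidinyloxy to hydroxypropyl-pyrrolidine on a flavone-like core

A few compounds are considered here, and "the series" means these few. Any claim that something is new, unique, unknown or untested is made for them only; others in the source may bear on it.

Measured compounds:
compound 1 `COc1cc(OC)c2c(=O)cc(-c3ccc(OCCBr)cc3)oc2c1`, a functional assay (Homo sapiens) for antiproliferative activity, read by resazurin assay, with a stated time of 48 h, tested at 10 uM; a higher number here means a stronger effect of the compound at the concentration tested, a lower number a weaker effect: "not active" (no number reported)
compound 2 `COc1cc(OC)c2c(=O)cc(-c3ccc(OC4CCNCC4)cc3)oc2c1`, this assay: 21%

Within the data shown here, compound 2 holds the only number reported here; compound 1 was recorded without one. Compound 3 `COc1cc(OC)c2c(=O)cc(-c3ccc(OCC(O)CN4CCCC4)cc3)oc2c1` differs from compound 2 in one place: 2-hydroxy-3-(pyrrolidin-1-yl)propyl in place of piperidin-4-yl on an oxygen on an aromatic ring. Among the measured compounds shown here, no measured pair shows what such a change does, so the expected step from compound 2 to compound 3 is small and uncertain in direction. Compound 3 is estimated at 25%, within 5% to 45%, which means an expected step of a number 4 percentage points higher from compound 2 to compound 3 (within the scatter), not clearly beyond the usual scatter.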

Compound 3, a percentage reported as inhibition, at one concentration (the size of the read-out at that concentration, not a potency): 37%
Beside the measured number, compound 3's estimate is 12 percentage points below it; measured number inside the range.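

On the oxygen on the aromatic ring, replacing piperidin-4-yl with 2-hydroxy-3-(pyrrolidin-1-yl)propyl in this assay gives a number 16 percentage points higher from compound 2 to compound 3 (beyond the scatter). This single change swaps a six-membered ring for a five-membered ring and also brings in a hydroxypropyl chain, so the step cannot be assigned to any one of these parts. Nothing available explains the rise. Open, from the compounds shown here alone, is whether the hydroxyl is needed, as a plain 3-(pyrrolidin-1-yl)propyl group would show. Also open, going by these compounds, is how a morpholine ring or a longer chain would fare here.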